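This account rests on a few compounds, and the source may have more. Where it says the series, first, only, none or still open, it means among the compounds named here.

Within the data shown here, in a functional assay on NCI-H1650 cells (Homo sapiens) for inhibition, read by sulforhodamine B assay, with a stated time of 3 days (on this read-out lower numbers stand for stronger inhibition and higher numbers for weaker inhibition), compound 1 (`O=C1Nc2ccc(F)cc2/C1=C\C(=O)c1ccc(O)cc1F`) gives 3460 nM and compound 2 (`COc1ccc(C(=O)Nc2ccc3c(c2)/C(=C/Nc2cccc(N4CCN(C)CC4)c2)C(=O)N3)cc1`) gives 1870 nM as the only two measured values so far. These two values lie within the usual scatter of each other, so the numbers do not set compound 2 apart from compound 1. Compound 3 (`CN1CCN(c2cccc(N/C=C3\C(=O)Nc4ccc(NC(=O)c5cccc(F)c5)cc43)c2)CC1`) has not yet been measured. It differs from compound 2 in one place (3-fluorophenyl in place of 4-methoxyphenyl on a carbonyl carbon) with 3-fluorophenyl in place of 4-methoxyphenyl on a carbonyl carbon whose other neighbour is an amide-type nitrogen. Each of the two groups is one six-membered aromatic ring of carbon only. Among the measured compounds shown here, no measured pair shows this exchange, so the data give no direct guide to its effect. The closest reference is compound 2 at 1870 nM in the same assay. In this assay no step beyond the scatter is expected in either direction. The estimated step (a 1.1-fold lower number from compound 2 to compound 3 (0.04 log units; within the scatter)) is small. For compound 3 the expected value is 1700 nM with an estimated range from 600 nM to 5000 nM for repeated measurements.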

Compound 3, half-maximal inhibitory concentration: 4280 nM
For compound 3 the middle estimate is 2.5-fold (0.40 log units) below the measured one; low and high end bracket the measured number.
By their numbers in this assay, from the lowest: compounds 2, 1 and 3 (each within the scatter of the next, the first and the last beyond it).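

In this assay, exchanging 4-methoxyphenyl for 3-fluorophenyl gives a 2.3-fold higher number from compound 2 to compound 3 (0.36 log units; beyond the scatter). Among these compounds, this is the first comparison here in which only one place differs, and it shows that the read-out responds to the group at this position, although the step is modest and both groups are one six-membered aromatic ring of carbon only. Nothing available explains the step.

The exchange alters the substituent on the ring and its place together, and it takes away the hydrogen-bond acceptor counted for 4-methoxyphenyl, so this single step cannot show which of these differences matters. The compounds shown also leave open how an unsubstituted phenyl, or a phenyl carrying an amine or a carboxylic acid, would read at this position, and whether the step would hold with other groups elsewhere on the shared core.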